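The source may report more compounds than this note shows. Statements on the series, on what has been measured and on what is new or still open speak of the compounds shown alone.

Compound 1 `O=[N+]([O-])c1ccc(-c2cn3nc(Cc4ccc(Cl)cc4)sc3n2)cc1` sits at the limit > 250000 nM in an ADME assay on CCRF-CEM cells (Homo sapiens) for cytotoxicity, with a stated time of 72 h (a lower number here means a stronger inhibitor, a higher number a weaker inhibitor), a limit rather than a number (the limit of > 250000 nM in this assay, at which 1 of the 3 values shown sits). Compound 2 `O=Cc1c(-c2ccc([N+](=O)[O-])cc2)nc2sc(Cc3ccc(Cl)cc3)nn12` gives 13000 nM in this assay, and the step of an at least 19-fold lower number from compound 1 to compound 2 (1.28 log units; beyond the scatter). Compound 3 `COc1ccc(-c2nc3sc(Cc4ccc(Cl)cc4)nn3c2SC#N)cc1` gives 10000 nM in this assay, the lowest of the two numbers, with compound 2 nearest and within the scatter. Compound 4 `N#CSc1c(-c2ccc([N+](=O)[O-])cc2)nc2sc(Cc3ccc(Cl)cc3)nn12` carries the change (nitro in place of methoxy on an aromatic carbon). Among the compounds with values here, no measured step concerns this change; compound 2 and compound 3 differ at two places, so their values show only that a nitro-bearing and a methoxy-bearing analogue land within the scatter of each other. For compound 4 the expected step is no change at the digits printed from compound 3 to compound 4 (within the scatter), none beyond the scatter. Compound 4 is estimated at 10000 nM, between 3000 nM and 40000 nM.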

Compound 4, half-maximal inhibitory concentration: 20000 nM
Beside the measured number, compound 4's estimate is 2.0-fold (0.30 log units) below it; measured number inside the range.
By their numbers in this assay, from the lowest: compounds 3, 2 and 4 (each within the scatter of the next). At a limit, above all of these: compound 1.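

In this assay, within the data shown here, the first direct reading of nitro in place of methoxy is a 2.0-fold higher number from compound 3 to compound 4 (0.30 log units; within the scatter), so this position accepts either group while cyanosulfanyl is present. With the 4-nitrophenyl group held, cyanosulfanyl and formyl do not separate, at a 1.5-fold higher number from compound 2 to compound 4 (0.19 log units; within the scatter), whereas cyanosulfanyl in place of hydrogen gives an at least 12-fold lower number from compound 1 to compound 4 (1.09 log units; beyond the scatter). The value of compound 1 is a limit, not a number: the limit of > 250000 nM in this assay, at which 1 of the 4 values shown sits.

Going by these compounds, whether an amine or a carboxylic acid in place of nitro would also stay within the scatter remains open. So does whether the methoxy-to-nitro result holds with formyl in place of cyanosulfanyl.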